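Biaryl benzimidazoles: fluorophenyl in place of methylphenyl

A few compounds are considered here, and "the series" means these few. Any claim that something is new, unique, unknown or untested is made for them only; others in the source may bear on it.

Compound 1 `N#Cc1ccc2nc(-c3ccc(-c4ccccc4F)cc3)[nH]c2c1` carries a nitrile on the shared core. In an assay on isolated protein for inhibition of acyl-CoA desaturase 1 (Rattus norvegicus) (a higher number here means a weaker inhibitor, a lower number a stronger inhibitor), compound 1 gives only a limit, > 20000 nM. Compound 2 `CN(C)S(=O)(=O)c1ccc2nc(-c3ccc(-c4ccccc4F)cc3)[nH]c2c1` carries dimethylsulfamoyl in the same place and gives 528 nM. Within the data shown here, the single step between neighbours, an at least 37-fold lower number from compound 1 to compound 2 (1.57 log units; beyond the scatter), concerns the substituent on the core. Compound 3 `Cc1ccc(-c2ccc(-c3nc4ccc(S(C)(=O)=O)cc4[nH]3)cc2)cc1` pairs methylsulfonyl with 4-methylphenyl. In this assay compound 3 gives only a limit, > 20000 nM. Among the measured compounds shown here, compound 3 thus stands at the limit of > 20000 nM in this assay, at which 2 of the 3 values shown sit, without a number of its own, and no measured step runs from it. Compound 4 `CS(=O)(=O)c1ccc2nc(-c3ccc(-c4cccc(F)c4)cc3)[nH]c2c1` differs by 3-fluorophenyl in place of 4-methylphenyl on an aromatic carbon. For the measured compounds named here, no measured step addresses the outer phenyl, so the step from compound 1 to compound 2 sets no size for this change. Compound 2, which also carries a fluorophenyl, does give a number. The expected step is an at least 3.3-fold lower number from compound 3 to compound 4 (0.52 log units; beyond the scatter), a move toward a measurable value with a real chance of another limit. The estimate for compound 4 is 6000 nM, within 1000 nM to 20000 nM.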

Compound 4, half-maximal inhibitory concentration: 21 nM
Compound 4: middle estimate off by 290-fold (2.46 log units), on the high side; measured number outside the range, below it.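

In this assay, the outer aryl group turns out to be a position that can take the series from a limit to a measured value: an at least 950-fold lower number from compound 3 to compound 4 (2.97 log units; beyond the scatter). Among these compounds, this is the first measured step at that position, and with methylsulfonyl held constant on the shared core, the whole change lies in 3-fluorophenyl replacing 4-methylphenyl. The printed size is only a floor, as compound 3 gives a limit and not a number: the limit of > 20000 nM in this assay, at which 2 of the 4 values shown sit.

The change alters both the substituent and where it sits on the outer ring, so the compounds shown cannot separate the contribution of fluorine from that of its placement. Matched 4-fluorophenyl and 3-methylphenyl groups would address this, while an amine or a carboxylic acid at the same place remains an open question.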